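Pyridinyl for phenyl at the ether oxygen, revisited

The source may report more compounds than this note shows. Statements on the series, on what has been measured and on what is new or still open speak of the compounds shown alone.

Compound 1 `CC(CCNC(=O)c1c(Cl)cncc1Cl)N1CCC(C(Oc2cccc(Cl)n2)c2ccc(C(F)(F)F)cc2)CC1`: > 32500 nM in an ADME assay on PBMC cells (Homo sapiens) for cytotoxicity (a higher number here means that more compound is tolerated, a lower number that less compound is tolerated), a limit of the assay, not a number.
Compound 2 `CC(CCNC(=O)c1c(Cl)cncc1Cl)N1CCC(C(Oc2cccc(Cl)c2)c2ccc(C(F)(F)F)cc2)CC1`: 8100 nM in this assay.

In this assay compound 2 holds the only number shown; compound 1 sits at a limit, (the limit of > 32500 nM in this assay, at which 1 of the 2 values shown sits). For the measured compounds named here, the one measured step, an at least 4.0-fold lower number from compound 1 to compound 2 (0.60 log units; beyond the scatter), lowered the tolerated concentration when a phenyl replaced a pyridinyl at this position. Compound 3 `Cc1cccc(OC(c2ccc(C(F)(F)F)cc2)C2CCN(C(C)CCNC(=O)c3c(Cl)cncc3Cl)CC2)n1` is not yet measured. It differs from compound 2 in 6-methylpyridin-2-yl in place of 3-chlorophenyl on an oxygen on a saturated carbon, so the aromatic ring at the oxygen on the saturated carbon again carries a nitrogen, as it does in compound 1. Since the step from compound 1 to compound 2 was at least modest and beyond the scatter, the reverse direction is expected here: for compound 3 a higher number in this assay than for compound 2, with a fair chance that only a limit is reported. The estimated step is a 3.1-fold higher number from compound 2 to compound 3 (0.49 log units; beyond the scatter). For compound 3 an estimate of 25000 nM, between 8000 nM and 45000 nM, is expected.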

Compound 3, half-maximal cytotoxic concentration: 6700 nM
For compound 3 the middle estimate is 3.7-fold (0.57 log units) above the measured one; the whole stated range lies above it.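

In this assay, the change to a ring carrying a nitrogen gave a 1.2-fold lower number from compound 2 to compound 3 (0.08 log units; within the scatter), so 6-methylpyridin-2-yl and 3-chlorophenyl cannot be told apart at this place on the oxygen on a saturated carbon. Between the two rings that carry a nitrogen, the change gave an at least 4.8-fold lower number from compound 1 to compound 3 (0.68 log units; beyond the scatter), which means the ring nitrogen alone does not set compound 1 apart; the methyl in place of chloro on an aromatic carbon counts as well. Compound 1 remains the only compound at a limit of the assay, not a number: the limit of > 32500 nM in this assay, at which 1 of the 3 values shown sits.

As far as these compounds go, it stays open whether a fluoro, a methoxy or a nitrile in place of that chloro on the pyridine ring would read like compound 1 or like compound 3. A 3-methylphenyl ring would show how methyl reads without the ring nitrogen, and the compounds shown do not settle that.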